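The source may report more compounds than this note shows. Statements on the series, on what has been measured and on what is new or still open speak of the compounds shown alone.

Of the compounds shown here, two have so far been measured in a functional assay on K562 cells (Homo sapiens) for antiproliferative activity, read by MTT assay, with a stated time of 48 h; a lower number here means a stronger inhibitor, a higher number a weaker inhibitor. Compound 1 (`Cn1cc(C2=C(c3nn(CCCN4CCCCC4)c4ncccc34)C(=O)N(c3ccc(Cl)cc3)C2=O)c2ccccc21`) gives 1800 nM, while compound 2 (`CN1CCN(CCCn2nc(C3=C(c4cn(C)c5ccccc45)C(=O)NC3=O)c3cccnc32)CC1`) gives 46700 nM. Compound 2 therefore holds the higher of the two numbers and is the weaker inhibitor, with a gap to compound 1 that lies beyond the scatter. Compound 3 (`Cn1cc(C2=C(c3nn(CCCN4CCCCC4)c4ncccc34)C(=O)NC2=O)c2ccccc21`) has not yet been measured. It departs from compound 2 in a single place, on a saturated chain carbon, three bonds along the chain from an aromatic nitrogen: piperidin-1-yl in place of 4-methylpiperazin-1-yl on a saturated chain carbon, three bonds along the chain from an aromatic nitrogen. Among the compounds with values here, compound 1 also carries the 3-(piperidin-1-yl)propyl group, but it differs from compound 3 elsewhere as well, so no measured pair shows this change alone. A moderate move towards lower numbers in this assay is nevertheless expected, resting only on the hint from compound 1 at 1800 nM, and a result within the scatter of compound 2 would not be surprising. The expected size of the step is a 3.1-fold lower number from compound 2 to compound 3 (0.49 log units; beyond the scatter). Compound 3 is estimated at 15000 nM, with an expected range from 5000 nM to 45000 nM.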

Compound 3, half-maximal inhibitory concentration: 5960 nM
Compound 3: middle estimate off by 2.5-fold (0.40 log units), on the high side, and the stated range covers the measured number.
By their numbers in this assay, from the lowest: compound 1; then compound 3; then compound 2.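

In this assay, the replacement of 4-methylpiperazin-1-yl by piperidin-1-yl on a saturated chain carbon, three bonds along the chain from an aromatic nitrogen, can now be read alone, and it gives a 7.8-fold lower number from compound 2 to compound 3 (0.89 log units; beyond the scatter). Compound 3 also isolates a second place, since hydrogen in place of 4-chlorophenyl on an amide-type nitrogen in a ring gives a 3.3-fold higher number from compound 1 to compound 3 (0.52 log units; beyond the scatter), so the 4-chlorophenyl compound holds the lower number of that pair. Nothing available explains either step.

The compounds shown do not tell whether morpholin-4-yl, a dimethylamino group or a longer chain in place of the 3-(piperidin-1-yl)propyl group would give a number lower or higher than that of compound 3, or whether a methyl group or an unsubstituted phenyl on the amide-type nitrogen would match 4-chlorophenyl. They also leave open whether the step from 4-methylpiperazin-1-yl to piperidin-1-yl keeps its size when 4-chlorophenyl sits on that nitrogen, and whether either step in this assay would hold on cells other than K562.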